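Compound 3: an untested exchange on a level pair

A few compounds are considered here, and "the series" means these few. Any claim that something is new, unique, unknown or untested is made for them only; others in the source may bear on it.

compound 1 `O=C(/C(=C\c1ccc(Br)cc1)Sc1ccc(Br)cc1)c1ccc(Br)cc1` gives 1000 nM
compound 2 `O=C(/C(=C\c1ccc(Br)c(O)c1)Sc1ccc(Br)cc1)c1ccc(Br)cc1` gives 1000 nM

Both values come from a functional assay on DU-145 cells (Homo sapiens) for inhibition, read by trypan blue exclusion, with a stated time of 96 h (a lower number here means a stronger inhibitor of growth, a higher number a weaker inhibitor of growth), and compound 2 stands level with compound 1, its nearest neighbour. Compound 3 `Nc1c(Br)cc(Br)cc1/C=C(/Sc1ccc(Br)cc1)C(=O)c1ccc(Br)cc1` has yet to be measured in this assay and is reached from compound 2 by one exchange. This is 2-amino-3,5-dibromophenyl in place of 4-bromo-3-hydroxyphenyl on a double-bonded chain carbon bound to a double-bonded chain carbon and it puts 2-amino-3,5-dibromophenyl in place of 4-bromo-3-hydroxyphenyl on a double-bonded chain carbon bound to a double-bonded chain carbon. Within the data shown here, only one measured step bears on it, no change at the digits printed from compound 1 to compound 2 (within the scatter) where hydroxy took the place of hydrogen on an aromatic carbon. That step is small evidence for a larger exchange, so no shift beyond the scatter is expected in this assay and the uncertainty stays wide. The estimated step is no change at the digits printed from compound 2 to compound 3 (within the scatter) on this reasoning. The value expected for compound 3 is 1000 nM within an estimated range of 250 nM to 4000 nM in this account.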

Compound 3, concentration for 50% growth inhibition: > 100000 nM
Compound 3: no number, only a limit; the forecaster's own chance of this, stated with the estimate: 5%; at least 100-fold (2.00 log units) between middle value and limit.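

In this assay, the group on a double-bonded chain carbon bound to a double-bonded chain carbon proves far from indifferent to exchange: 2-amino-3,5-dibromophenyl in place of 4-bromo-3-hydroxyphenyl gives an at least 100-fold higher number from compound 2 to compound 3 (2.00 log units; beyond the scatter), and the same group in place of 4-bromophenyl gives an at least 100-fold higher number from compound 1 to compound 3 (2.00 log units; beyond the scatter). The earlier pair showed only that a hydroxy could take the place of hydrogen with no step beyond the scatter, whereas this exchange shows that the same position can respond strongly. The reading for compound 3 is a limit of the assay and not a number: the limit of > 100000 nM in this assay, at which 1 of the 3 values shown sits.

The exchange brings in the amino and bromo groups of 2-amino-3,5-dibromophenyl together, and the compounds shown cannot separate their shares in the step. Going by these compounds, it also remains open how a 2-aminophenyl group or a carboxylic acid at this place would read in this assay.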